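A few compounds are considered here, and "the series" means these few. Any claim that something is new, unique, unknown or untested is made for them only; others in the source may bear on it.

Three compounds have numbers in a physicochemical assay for solubility, read by HPLC, in phosphate buffer, with a stated time of 16 h, at pH 6.8; a lower number here means a less soluble compound, a higher number a more soluble compound. Compound 1 (`COc1ccc([C@H](C)NC(=O)Cn2nnc3ccccc3c2=O)cc1`) gives 15000 nM, compound 2 (`COc1ccc2nnn(CC(=O)N[C@@H](C)c3ccc(C)cc3)c(=O)c2c1`) gives 2300 nM, and compound 3 (`Cc1ccc([C@H](C)NC(=O)Cn2nnc3ccc(C)cc3c2=O)cc1`) gives 3100 nM. Compound 3 thus lies within the scatter of compound 2, while compound 1 stands clear of both. Compound 4 (`Cc1ccc([C@H](C)NC(=O)Cn2nnc3ccc(F)cc3c2=O)cc1`) carries fluoro in place of methyl on an aromatic carbon. The closest measured change is a 1.3-fold higher number from compound 2 to compound 3 (0.13 log units; within the scatter), with methyl in place of methoxy on an aromatic carbon, and it stays within the scatter. Compound 1 differs from compound 3 in more than one place, so it offers no clean comparison. In this assay the expected step is therefore a 1.1-fold higher number from compound 3 to compound 4 (0.05 log units; within the scatter), which would lie within the scatter. For compound 4 the estimated value is 3500 nM, with an expected range from 1300 nM to 9000 nM.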

Compound 4, solubility: 3400 nM
Beside the measured number, compound 4's estimate is 1.0-fold (0.01 log units) above it; measured number inside the range.
By their numbers in this assay, from the lowest: compounds 2, 3 and 4 (each within the scatter of the next); then compound 1.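

Fluoro in place of methyl on this aromatic carbon gives a 1.1-fold higher number from compound 3 to compound 4 (0.04 log units; within the scatter) in this assay, and fluoro in place of methoxy gives a 1.5-fold higher number from compound 2 to compound 4 (0.17 log units; within the scatter). Both steps stay within the scatter, so methoxy, methyl and fluoro at this position cannot be told apart by this read-out. Nothing available here offers an explanation for this result.

Going by these compounds, whether an amine or a carboxylic acid on this carbon would give a number beyond the scatter remains open. On these data alone, compound 1 differs from these compounds in more than one place, so the source of its separate number also remains open.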